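Replacing the Pyrrolidine Ring with a Larger Acetoxypiperidine

The source may hold more compounds than are shown below. What is called first, only, known or untested is meant among the compounds shown, and "the series" means these compounds.

Measured so far in a functional assay on CHO-K1 cells for antagonist activity at transient receptor potential cation channel subfamily V member 1 (Homo sapiens), read by FLIPR; on this read-out higher numbers stand for weaker inhibition and lower numbers for stronger inhibition:
Compound 1, `CC(C(=O)NCc1ccc(C(F)(F)F)nc1N(C)C)c1ccc(NS(C)(=O)=O)c(F)c1`, gives 2390 nM.
Compound 2, `CC(C(=O)NCc1ccc(C(F)(F)F)nc1N1CCCC1)c1ccc(NS(C)(=O)=O)c(F)c1`, gives 211 nM.
Compound 3, `C[C@@H](C(=O)NCc1ccc(C(F)(F)F)nc1N1CCC(c2ccccc2)CC1)c1ccc(NS(C)(=O)=O)c(F)c1`, gives 2350 nM.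

Compound 2 stands at the lowest number of the three; compound 1 and compound 3 both sit well above it, beyond the scatter. Going by the values given here, the only single-place step in this set is an 11-fold lower number from compound 1 to compound 2 (1.05 log units; beyond the scatter), where pyrrolidin-1-yl replaced dimethylamino on the aromatic carbon and the number fell sharply.

Compound 4, `CC(=O)OC1CCN(c2nc(C(F)(F)F)ccc2CNC(=O)C(C)c2ccc(NS(C)(=O)=O)c(F)c2)CC1`, continues from compound 2 with a change at the same place: 4-acetoxypiperidin-1-yl in place of pyrrolidin-1-yl on an aromatic carbon. Among the compounds with values here, the step from compound 1 to compound 2 shows that this position tolerates a change of the amine, but the only other compound carrying a six-membered ring there, compound 3, gives a number far above compound 2. Compound 4 is therefore expected to move upward, by a 3.8-fold higher number from compound 2 to compound 4 (0.58 log units; beyond the scatter), to an estimated 800 nM with a range from 250 nM to 2500 nM.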

Compound 4, half-maximal inhibitory concentration: 139 nM
Beside the measured number, compound 4's estimate is 5.8-fold (0.76 log units) above it; the measured number lies below the stated range.
By their numbers in this assay, from the lowest: compounds 4 and 2 (each within the scatter of the next); then compounds 3 and 1 (each within the scatter of the next).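

In this assay, the step to 4-acetoxypiperidin-1-yl gives a 1.5-fold lower number from compound 2 to compound 4 (0.18 log units; within the scatter) and so leaves the number level with the pyrrolidine, although the entering group is the larger one. The same group also gives a 17-fold lower number from compound 1 to compound 4 (1.24 log units; beyond the scatter) and thus keeps the large gain over dimethylamino, which shows that this position is not limited to the small pyrrolidin-1-yl ring. A six-membered ring here therefore does not by itself bring a high number, though compound 3, also a piperidine, gives (2350 nM) and goes against any simple rule; it also differs from compound 4 in its defined stereocentre.

Whether the acetoxy group contributes remains open, since neither the unsubstituted piperidin-1-yl nor 4-hydroxypiperidin-1-yl stands among these compounds. Morpholin-4-yl at this place is equally open. No evidence is at hand that would explain this result.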